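Swapping a pyridin-3-yl for methoxy in a salicylanilide series

The compounds below may be only part of what the source reports. "The series", "measured", "known", "first", "only" and "open" are said of these compounds alone.

Compounds measured so far in a functional assay on KG-1 cells (Homo sapiens) for cytotoxicity, read by luminescence and CellTiter-Glo, with a stated time of 3 days; a lower number here means a stronger inhibitor, a higher number a weaker inhibitor:
- compound 1, `N#Cc1ccc(NC(=O)c2ccc(-c3cccnc3)cc2O)cc1`, gives 7940 nM
- compound 2, `O=C(Nc1ccc(C(F)(F)F)c(Cl)c1)c1cc(Cl)ccc1O`, gives 450 nM
- compound 3, `Cc1cccc(C(=O)Nc2ccc(C#N)cc2)c1O`, gives 8980 nM

Among these three numbers compound 1 sits second highest. Compound 3 is nearest to it, a gap within the scatter of this assay, so no order can be read between them. Compound 2 lies furthest away, with a much lower number, a gap beyond the scatter.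

Compound 4, `COc1ccc(C(=O)Nc2ccc(C#N)cc2)c(O)c1`, is not yet measured. It differs from compound 1 in one place: methoxy in place of pyridin-3-yl on an aromatic carbon.

Among the measured compounds shown here, with no measured step of this kind to lean on, and compound 1 and compound 3 both giving weak numbers, compound 4 is expected to stay close to compound 1, a step of a 1.1-fold higher number from compound 1 to compound 4 (0.05 log units; within the scatter) that is not expected to reach beyond the scatter. The estimate for compound 4 is 9000 nM, with a range from 3000 nM to 30000 nM.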

Compound 4, half-maximal inhibitory concentration: 5430 nM
For compound 4 the middle estimate is 1.7-fold (0.22 log units) above the measured one, and the stated range covers the measured number.
By their numbers in this assay, from the lowest: compound 2; then compounds 4, 1 and 3 (each within the scatter of the next).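

At this place, on an aromatic carbon para to a large group, methoxy in place of pyridin-3-yl gives a 1.5-fold lower number from compound 1 to compound 4 (0.17 log units; within the scatter) in this assay and so shows no readable change. The aromatic ring can therefore give way to a group with no ring while the number stays weak. Nothing measured here explains this result.

From the compounds shown here alone, whether an amine or a carboxylic acid at this place would move the number beyond the scatter stays open. So does the effect of a longer chain, such as butoxy, here.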